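A methoxy swap at the edge of the assay's range

A few compounds are considered here, and "the series" means these few. Any claim that something is new, unique, unknown or untested is made for them only; others in the source may bear on it.

In a functional assay on HCT-116 cells (Homo sapiens) for inhibition, read by CCK-8 assay, with a stated time of 48 h (a higher number here means a weaker inhibitor, a lower number a stronger inhibitor), compound 3 `COc1ccc(CN(C(=O)CSC(=S)N2CCN(C(=O)OC(C)(C)C)CC2)c2ccc(C)cc2)cc1` gives > 20000 nM, which is a limit and not a number. Compound 1 `COc1ccc(CN(C(=O)CSC(=S)N2CCN(C(=O)OC(C)(C)C)CC2)c2ccc(Cl)cc2)cc1` gives > 20000 nM, also a limit. Compound 2 `COc1ccc(CN(C(=O)CSC(=S)N2CCN(C(=O)OC(C)(C)C)CC2)c2ccccc2)cc1` gives > 20000 nM, again a limit. The whole picture so far is the limit of > 20000 nM in this assay, at which 3 of the 3 values shown sit.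

Compound 4 `COc1ccc(CN(C(=O)CSC(=S)N2CCN(C(=O)OC(C)(C)C)CC2)c2ccc(OC)cc2)cc1` differs from compound 3 by methoxy in place of methyl on an aromatic carbon, turning 4-methylphenyl into 4-methoxyphenyl.

Three measured steps alter that same group: a step that the two limits leave unreadable from compound 1 to compound 2, a step that the two limits leave unreadable from compound 2 to compound 3 and a step that the two limits leave unreadable from compound 1 to compound 3. None has a readable size, so they offer no size or direction to carry over. They show only that chloro, hydrogen and methyl all left the compounds at the limit. The expected change is therefore a step that the limit leaves unreadable from compound 3 to compound 4, with no firm direction. For compound 4 the estimate is 25000 nM, with an expected range of 10000 nM to 50000 nM. Most likely, this assay will again report only a limit.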

Compound 4, half-maximal inhibitory concentration: > 20000 nM
Compound 4: only a limit was reported (the forecaster's own chance of this, stated with the estimate: 85%); the middle value does not contradict the limit.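

Compound 4 gives > 20000 nM here, again a limit, so its steps from compound 1, compound 2 and compound 3 cannot be read. The compounds shown leave open whether any group on this aromatic carbon, or any change elsewhere on the shared core, would give a readable value in this assay at all.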